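The compounds below may be only part of what the source reports. "The series", "measured", "known", "first", "only" and "open" are said of these compounds alone.

Of the compounds shown here, two built on a shared core have been measured in an assay on HEK293 cells for displacement of a labelled ligand from metabotropic glutamate receptor 5 (Homo sapiens), with a stated time of 2 h; on this read-out lower numbers stand for stronger inhibition and higher numbers for weaker inhibition. Compound 1 `Cc1ccc(C#Cc2ccc3c(n2)CCN(C)C3=O)cc1` gives 7450 nM. Compound 2 `CN1CCc2nc(C#Cc3cccnc3)ccc2C1=O` gives 27400 nM. For the measured compounds named here, compound 1 therefore stands at the lower of the two numbers, and the single measured step, a 3.7-fold higher number from compound 1 to compound 2 (0.57 log units; beyond the scatter), concerns pyridin-3-yl in place of 4-methylphenyl on a triple-bonded carbon. Compound 3 `Cc1ccc(C#Cc2ccc3c(n2)CCN(C2CCCCC2)C3=O)cc1` has not yet been measured. It differs from compound 1 by cyclohexyl in place of methyl on an amide-type nitrogen in a ring. Going by the values given here, the only measured step lies at the triple-bonded carbon, not at the amide-type nitrogen in the ring, so it does not bear on this change, and the measured data give no guide to its size or direction. In the absence of such a guide, compound 3 is expected to land near compound 1, with a wide range on either side. The estimate for compound 3 is 5000 nM, between 1000 nM and 30000 nM. That corresponds to an expected step of a 1.5-fold lower number from compound 1 to compound 3 (0.17 log units; within the scatter).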

Compound 3, inhibition constant: 27200 nM
Beside the measured number, compound 3's estimate is 5.4-fold (0.74 log units) below it; the measured number falls inside the stated range.
By their numbers in this assay, from the lowest: compound 1; then compounds 3 and 2 (each within the scatter of the next).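

In this assay, the amide-type nitrogen in the ring turns out to be a position where the group matters, which the earlier step at the triple-bonded carbon could not show: cyclohexyl in place of methyl gives a 3.7-fold higher number from compound 1 to compound 3 (0.56 log units; beyond the scatter). The change is modest, and binding remains measurable with the six-membered non-aromatic ring of carbon only in place, yet this larger group does not improve on methyl. Nothing available on these compounds accounts for the shift.

With only methyl and cyclohexyl shown at this nitrogen, it remains open whether the number tracks the size of the group or the presence of a ring, a question that an ethyl group, a longer open chain or a cyclopropyl ring could address. Going by these compounds, how a group carrying an amine or a hydroxyl would behave at this position also remains unknown.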